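This account rests on a few compounds, and the source may have more. Where it says the series, first, only, none or still open, it means among the compounds named here.

Compound 2 `Cc1cc(NC(=O)Cn2nnc(-c3cccc(F)c3)n2)n(C2CCCCC2)n1` reaches 96% in an assay on HEK293 cells for activation of Kir3.1/Kir3.2 (Homo sapiens), read by thallium flux (on this read-out lower numbers stand for smaller maximal responses and higher numbers for larger maximal responses), the higher of the two numbers at hand. Its nearest neighbour is compound 1 `Cc1cc(NC(=O)Cn2nnc(-c3ccccc3)n2)n(C2CCCCC2)n1`, which gives 92% in this assay; the step of a number 4 percentage points higher from compound 1 to compound 2 (within the scatter) stays within the scatter. Compound 3 `Cc1cc(NC(=O)Cn2nnc(-c3ccc(F)c(F)c3)n2)n(C2CCCCC2)n1` differs from compound 2 by fluoro in place of hydrogen on an aromatic carbon. For the measured compounds named here, the only step that bears on this change is the one from compound 1 to compound 2, which added a fluoro group in the same way and hardly moved the number. A step of similar size is therefore expected in this assay, which means none beyond the scatter, giving no change at the digits printed from compound 2 to compound 3 (within the scatter). Compound 3 is thus estimated at 96%, within 84% to 106%.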

Compound 3, largest response reached (Emax), in percent of the reference or control that the assay uses: 93%
Compound 3: the middle estimate sits 3 percentage points above what was measured; the measured number falls inside the stated range.
By their numbers in this assay, from the lowest: compounds 1, 3 and 2 (each within the scatter of the next).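

In this assay a second fluoro group, ortho to the first and para to a large group, gives a number 3 percentage points lower from compound 2 to compound 3 (within the scatter) and so leaves the maximal response unchanged within the scatter. Taken together, the two fluoro groups also make no clear difference to the unsubstituted phenyl compound, with a number 1 percentage points higher from compound 1 to compound 3 (within the scatter) as the printed step. Nothing available here explains this flat result. Fluoro is the only group shown at this position. A methoxy group, an amine or a carboxylic acid there could give a different response.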